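A Fluoro Group on Compound 1's Outer Phenyl

The source may report more compounds than this note shows. Statements on the series, on what has been measured and on what is new or still open speak of the compounds shown alone.

In an ADME assay on microsomes from liver (Homo sapiens), read by LC-MS, using NADPH, with a stated time of 10 min, tested at 0.5 uM (a higher number here means that more of the compound is left, a lower number that less of the compound is left), compound 1 `Cc1nc2cc(-c3cccc(-c4ccccc4)c3)nn2c(-c2cc(F)c3c(c2C)CCCO3)c1[C@H](OC(C)(C)C)C(=O)O` gives 78%. Compound 2 `Cc1nc2cc(-c3cccc(-c4ccccc4)c3)nn2c(-c2cc(F)c3c(c2C)CCCO3)c1C(OC(C)(C)C)C(=O)O` gives 86%, and the step of a number 8 percentage points higher from compound 1 to compound 2 (within the scatter) stays within the usual scatter. The only thing separating these two is the fact that one of compounds 1 and 2 is drawn with a defined configuration and the other without, at the place where they differ. Compound 3 `Cc1nc2cc(-c3cccc(OCc4ccccc4)c3)nn2c(N2CCC(C)(C)CC2)c1C(OC(C)(C)C)C(=O)O`, which has a different structure, gives 100%, a gap from compound 1 that lies beyond the scatter.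

The unmeasured compound 4 `Cc1nc2cc(-c3cccc(-c4ccccc4F)c3)nn2c(-c2cc(F)c3c(c2C)CCCO3)c1[C@H](OC(C)(C)C)C(=O)O` departs from compound 1 by fluoro in place of hydrogen on an aromatic carbon, which turns phenyl into 2-fluorophenyl. For the measured compounds named here, no measured step tests this kind of change. Going by the values given here, the single step available, a number 8 percentage points higher from compound 1 to compound 2 (within the scatter), concerns only how a stereocentre is drawn. With no evidence for a shift in either direction, no step beyond the scatter is expected, and compound 1 remains the natural starting point. The estimated step of a number 2 percentage points higher from compound 1 to compound 4 (within the scatter) is expected to stay within the scatter. For compound 4 the expected value is 80%, with an estimated range from 66% to 94%.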

Compound 4, percent of the compound remaining: 100%
Estimate against measurement, compound 4: 20 percentage points below; measured number above the stated range.
By their numbers in this assay, from the lowest: compounds 1 and 2 (each within the scatter of the next); then compounds 3 and 4 (each within the scatter of the next).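

In this assay, the change from phenyl to 2-fluorophenyl comes out as a number 22 percentage points higher from compound 1 to compound 4 (beyond the scatter). For the compounds shown here, compound 1 and compound 2 carry the same phenyl and differ only in how a stereocentre is drawn, so this is the first evidence that a small change on this outer ring, a single fluoro in place of hydrogen, can move the amount of compound left by more than the scatter. Nothing shown bears on why the number moves here.

Whether this result belongs to fluoro in particular remains open, since the compounds shown do not include chloro, methyl, methoxy or a nitrile at this place. Also open, as far as these compounds go, is whether fluoro at other places on this ring, or a second fluoro, would give a similar number.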